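Exchanging the ring on the alkyne of compound 2

The compounds below may be only part of what the source reports. "The series", "measured", "known", "first", "only" and "open" are said of these compounds alone.

Compound 1 `COC(=O)c1sc2cc(C#Cc3ccccn3)cnc2c1N`: 13900 nM
Compound 2 `COC(=O)c1sc2cc(C#Cc3ccc(N)cc3)cnc2c1N`: 4800 nM

Both numbers come from a functional assay on A375-C5 cells (Homo sapiens) for inhibition, read by sulforhodamine B assay, with a stated time of 48 h; on this read-out higher numbers stand for weaker inhibition of growth and lower numbers for stronger inhibition of growth. Compound 2 stands at the lower of the two numbers, and the step of a 2.9-fold lower number from compound 1 to compound 2 (0.46 log units; beyond the scatter) lies beyond the scatter. Compound 3 `COC(=O)c1sc2cc(C#Cc3ccsc3)cnc2c1N` differs from compound 2 in one place: thiophen-3-yl in place of 4-aminophenyl on a triple-bonded carbon. Among the measured compounds shown here, the only measured step that bears on this exchange of the ring on the triple-bonded carbon is a 2.9-fold lower number from compound 1 to compound 2 (0.46 log units; beyond the scatter), a modest one. Because the step of a 2.9-fold lower number from compound 1 to compound 2 (0.46 log units; beyond the scatter) followed the entry of 4-aminophenyl, its removal in compound 3 is expected to bring a modest rise, a 1.9-fold higher number from compound 2 to compound 3 (0.27 log units; within the scatter). Compound 3 is estimated at 9000 nM, within a range of 3000 nM to 27000 nM.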

Compound 3, concentration for 50% growth inhibition: 29600 nM
Estimate against measurement, compound 3: 3.3-fold (0.52 log units) below; measured number above the stated range.
By their numbers in this assay, from the lowest: compound 2; then compound 1; then compound 3.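

Placing thiophen-3-yl on the triple-bonded carbon gives a 6.2-fold higher number from compound 2 to compound 3 (0.79 log units; beyond the scatter) and also a 2.1-fold higher number from compound 1 to compound 3 (0.33 log units; beyond the scatter), which makes compound 3 the weakest of the three at inhibiting growth. The ring at this position therefore matters more than the first pair suggested, since the thiophen-3-yl ring falls behind both six-membered rings. Nothing measured here explains this order. Still open, as far as these compounds go, is whether the advantage of compound 2 comes from its amine or from its carbon-only ring, a question that a plain phenyl at this position would help to settle.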